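The source may hold more compounds than are shown below. What is called first, only, known or untested is meant among the compounds shown, and "the series" means these compounds.

Measured compounds:
compound 1, `Cc1nc(SCC(=O)Nc2nc(-c3ccc(Cl)cc3)cs2)n(Nc2ccccc2)c1C`, 5240 nM
compound 2, `Cc1ccc(Nn2c(SCC(=O)Nc3nc(-c4ccccc4)cs3)nc(C)c2C)cc1`, 10400 nM

Both were tested in a functional assay on T47D cells (Homo sapiens) for antiproliferative activity, read by sulforhodamine B assay, with a stated time of 48 h; a lower number here means a stronger inhibitor of growth, a higher number a weaker inhibitor of growth. Compound 1 gives 5240 nM, and compound 2 gives 10400 nM; these two numbers lie within the usual scatter of each other, so neither compound can be said to inhibit growth more strongly than the other. Compound 3, `COc1ccc(Nn2c(SCC(=O)Nc3nc(-c4ccc(Cl)cc4)cs3)nc(C)c2C)cc1`, has not yet been measured. It differs from compound 1 in one place: methoxy in place of hydrogen on an aromatic carbon, on a six-membered aromatic ring of carbon only. Among the measured compounds shown here, no pair of measured compounds shows this same change, so there is nothing to calibrate its size against. With so small an addition, and with the two measured compounds so close together, the step is expected to be small, in no clear direction, and not beyond the scatter: a 1.1-fold higher number from compound 1 to compound 3 (0.06 log units; within the scatter). Compound 3 is therefore estimated at 6000 nM in this assay, within a range from 2500 nM to 15000 nM.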

Compound 3, concentration for total growth inhibition: 8040 nM
For compound 3 the middle estimate is 1.3-fold (0.13 log units) below the measured one, within the range that was stated.
By their numbers in this assay, from the lowest: compounds 1, 3 and 2 (each within the scatter of the next).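

Among the compounds shown here, the first comparison in this set that differs in only one place turns the anilino group of compound 1 into the (4-methoxyphenyl)amino group of compound 3, and it gives a 1.5-fold higher number from compound 1 to compound 3 (0.19 log units; within the scatter) in this assay. Methoxy can therefore stand in place of hydrogen at this position, para to a large group, with no difference in growth inhibition that can be told apart from the spread of repeated measurements. No supporting measurement bears on this result, so the size of the step stays unexplained.

Going by these compounds, it remains open whether a different group at this same place, such as an amine or a carboxylic acid, would give a step beyond the scatter. Also open, on these data alone, is whether methoxy elsewhere on this ring would give a similarly small step.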